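Pyrimidinyl piperazine variant in a growth-inactive triazine set

This account rests on a few compounds, and the source may have more. Where it says the series, first, only, none or still open, it means among the compounds named here.

Compound 3 `CC(C)N1CCN(c2nc(Nc3ccc(C#N)c(C(F)(F)F)c3)nc(Oc3ccnc4ccccc34)n2)CC1` is one of three close relatives examined in a functional assay on DU-145 cells (Homo sapiens) for cytotoxicity, read by sulforhodamine B assay, with a stated time of 48 h; a higher number here means a weaker inhibitor of growth, a lower number a stronger inhibitor of growth. In this assay compound 3 gives > 100000 nM, which is a limit of the assay and not a number. Compound 1 `N#Cc1ccc(Nc2nc(Oc3ccnc4ccccc34)nc(N3CCN(c4ccccc4Cl)CC3)n2)cc1C(F)(F)F` gives > 100000 nM in this assay, likewise a limit. Compound 2 `COc1ccc(CN2CCN(c3nc(Nc4ccc(C#N)c(C(F)(F)F)c4)nc(Oc4ccnc5ccccc45)n3)CC2)c(OC)c1OC` gives > 100000 nM in this assay, also a limit. Among the measured compounds shown here, the only pair differing in one place is a step that the two limits leave unreadable from compound 1 to compound 3, and with both ends at a limit its size cannot be read. For the measured compounds named here, every value shown sits at the limit of > 100000 nM in this assay, at which 3 of the 3 values shown sit, so no measured step is of readable size.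

Compound 4 `N#Cc1ccc(Nc2nc(Oc3ccnc4ccccc34)nc(N3CCN(c4ncccn4)CC3)n2)cc1C(F)(F)F` differs from compound 3 by pyrimidin-2-yl in place of isopropyl on an amine nitrogen in a ring. Compound 1 already carries a six-membered aromatic ring on that same ring nitrogen, and since compound 1 gives only > 100000 nM, an aromatic group there has not so far brought growth inhibition into the measurable range. Going by the values given here, no step bears readably on the change, so the expectation is simply that the limit persists. The step of a number no higher from compound 3 to compound 4 (the limit leaves the size open) is expected to be nothing beyond the scatter. Compound 4 is therefore expected to give about 100000 nM, with a range from 30000 nM to 300000 nM.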

Compound 4, concentration for total growth inhibition: > 100000 nM
Compound 4: no number, only a limit (the forecaster's own chance of this, stated with the estimate: 85%); the middle value sits exactly at the limit.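

Compound 4, like compound 1 and compound 3, gives only a limit in this assay and not a number, so no step joining compound 4 to compound 1 or compound 3 can be read: the limit of > 100000 nM in this assay, at which 4 of the 4 values shown sit.

The compounds shown leave open whether any group on the amine nitrogen in a ring can bring growth inhibition in this assay into the measurable range.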